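From Bromo to Carboxy in a Growth-Inhibition Series

The source may hold more compounds than are shown below. What is called first, only, known or untested is meant among the compounds shown, and "the series" means these compounds.

In a functional assay on DU-145 cells (Homo sapiens) for inhibition, read by trypan blue exclusion, with a stated time of 96 h (on this read-out lower numbers stand for stronger inhibition of growth and higher numbers for weaker inhibition of growth), compound 3 `CN(C)c1ccc(/C=C(/SCc2ccc(F)cc2)C(=O)c2ccc(Br)cc2)cc1` gives 50000 nM. That is a higher number, and so weaker inhibition of growth, than the value of compound 2 `O=C(O)c1ccc(C(=O)/C(=C\c2ccc(Cl)c([N+](=O)[O-])c2)SCc2ccc(F)cc2)cc1` at 1000 nM. Compound 1 `O=C(O)c1ccc(C(=O)/C(=C\c2ccc(Br)cc2)SCc2ccc(F)cc2)cc1` gives > 100000 nM, which is a limit of the assay and not a number.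

The next structure, compound 4 `CN(C)c1ccc(/C=C(/SCc2ccc(F)cc2)C(=O)c2ccc(C(=O)O)cc2)cc1`, differs from compound 3 by one swap: carboxy in place of bromo on an aromatic carbon. Carboxy takes the place of bromo on an aromatic carbon, turning 4-bromophenyl into 4-carboxyphenyl. Among the measured compounds shown here, compound 1 and compound 2 already carry 4-carboxyphenyl, but no measured step makes this exact swap. For the measured compounds named here, the one measured step, an at least 100-fold lower number from compound 1 to compound 2 (2.00 log units; beyond the scatter), is large, yet it puts 4-chloro-3-nitrophenyl in place of 4-bromophenyl elsewhere in the molecule. It shows that compounds with 4-carboxyphenyl can lie far apart in this assay, but it gives no direction for the swap at hand. The expectation is therefore no step beyond the scatter, held with wide uncertainty, and the estimated change is a 1.7-fold lower number from compound 3 to compound 4 (0.22 log units; within the scatter). For compound 4 the estimated value is 30000 nM, with an expected range from 3000 nM to 100000 nM.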

Compound 4, concentration for 50% growth inhibition: 10000 nM
Compound 4: the middle estimate sits 3.0-fold (0.48 log units) above what was measured, and the stated range covers the measured number.
By their numbers in this assay, from the lowest: compound 2; then compound 4; then compound 3. At a limit, above all of these: compound 1.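

Read on its own, the swap of 4-bromophenyl to 4-carboxyphenyl now has a direction, since in this assay it brings a 5.0-fold lower number from compound 3 to compound 4 (0.70 log units; beyond the scatter), a modest step but one beyond the scatter. With 4-carboxyphenyl held in place, the group on the other aromatic ring still matters: a 10-fold higher number from compound 2 to compound 4 (1.00 log units; beyond the scatter) comes with 4-(dimethylamino)phenyl in place of 4-chloro-3-nitrophenyl, and an at least 10-fold lower number from compound 1 to compound 4 (1.00 log units; beyond the scatter) comes with dimethylamino in place of bromo, so among compounds 1, 2 and 4 the carboxy group alone does not settle the result. Compound 1 sits at a limit of the assay and not at a number: the limit of > 100000 nM in this assay, at which 1 of the 4 values shown sits.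

From the compounds shown here alone, only compound 3 and compound 4 test this swap, so it remains open whether carboxy in place of bromo would move the number the same way with 4-chloro-3-nitrophenyl on the other side of the molecule. The compounds shown also leave open how a methyl ester or a primary amide would compare with carboxy on this aromatic carbon.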